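Adding a methyl to the alkene: compound 4 versus compound 1

A few compounds are considered here, and "the series" means these few. Any claim that something is new, unique, unknown or untested is made for them only; others in the source may bear on it.

Compound 1 `Cc1nc(N2CCC(O)CC2)nc2ccc(NC(=O)/C=C/c3ccc(Cl)cc3)cc12` is the reference point. Within the data shown here, in an assay on CHO-K1 cells for displacement of a labelled ligand from melanin-concentrating hormone receptor 1 (Homo sapiens), read by scintillation proximity assay, with a stated time of 2 h (a higher number here means a weaker inhibitor, a lower number a stronger inhibitor), compound 1 gives 107 nM, the second highest of the three numbers so far. Compound 2 `Cc1nc(N2CCC(N3CCCC3=O)CC2)nc2ccc(NC(=O)/C=C/c3ccc(Cl)cc3)cc12` gives 74 nM in this assay, and the step of a 1.4-fold lower number from compound 1 to compound 2 (0.16 log units; within the scatter) stays within the scatter. Compound 3 `COCCC1(O)CCN(c2nc(C)c3cc(NC(=O)/C=C/c4ccc(Cl)cc4)ccc3n2)CC1` gives 245 nM in this assay, and the step of a 2.3-fold higher number from compound 1 to compound 3 (0.36 log units; beyond the scatter) is a modest loss. Both of these changes sit on the saturated ring, away from the amide end.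

Compound 4 `C/C(=C\C(=O)Nc1ccc2nc(N3CCC(O)CC3)nc(C)c2c1)c1ccc(Cl)cc1` differs from compound 1 at the amide end: 2-(4-chlorophenyl)prop-1-en-1-yl in place of 2-(4-chlorophenyl)ethenyl on a carbonyl carbon. Among the measured compounds shown here, no measured step touches this part of the molecule; the steps from compound 1 to compound 2 and to compound 3 concern the saturated ring only, so they give no direct guidance. The change adds one carbon and leaves donors, acceptors and charge unchanged. The expected step is a 1.2-fold higher number from compound 1 to compound 4 (0.08 log units; within the scatter), which is taken to stay within the scatter. Compound 4 is estimated at 130 nM, within a range of 50 nM to 350 nM.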

Compound 4, half-maximal inhibitory concentration: 670 nM
Compound 4: middle estimate off by 5.2-fold (0.71 log units), on the low side; measured number outside the range, above it.
By their numbers in this assay, from the lowest: compounds 2 and 1 (each within the scatter of the next); then compound 3; then compound 4.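

In this assay (this assay), 2-(4-chlorophenyl)prop-1-en-1-yl in place of 2-(4-chlorophenyl)ethenyl on a carbonyl carbon gives a clear loss (a 6.3-fold higher number from compound 1 to compound 4 (0.80 log units; beyond the scatter)). The amide end thus responds to one added carbon, with donors, acceptors and charge unchanged, and this step from compound 1 is larger than either step on the saturated ring (a 1.4-fold lower number from compound 1 to compound 2 (0.16 log units; within the scatter); a 2.3-fold higher number from compound 1 to compound 3 (0.36 log units; beyond the scatter)). No measurement shown accounts for the loss.

Still open, as far as these compounds go, is whether the loss is specific to the added methyl, which 2-(4-chlorophenyl)but-1-en-1-yl, with an ethyl in its place, or saturated 2-(4-chlorophenyl)ethyl could help test. Also open, from the compounds shown here alone, is whether the same change costs as much when the saturated ring carries the 2-oxopyrrolidin-1-yl group of compound 2.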